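This account rests on a few compounds, and the source may have more. Where it says the series, first, only, none or still open, it means among the compounds named here.

Series notes. Compound 1 `CCc1nnc(-c2ccc(-c3ccccc3)cc2)n1-c1ccccc1C` gives 300 nM in an assay on C6 glioma cells for displacement of a labelled ligand from sodium- and chloride-dependent glycine transporter 1 (Rattus norvegicus), read by scintillation counting, with stated times of 30 min and 10 min; on this read-out higher numbers stand for weaker inhibition and lower numbers for stronger inhibition. Compound 2 `CCc1nnc(-c2ccc(-c3ccccc3)cc2)n1-c1cccc(C)c1C` carries a methyl in place of hydrogen on an aromatic carbon of the shared core and gives 940 nM in this assay; the step reads a 3.1-fold higher number from compound 1 to compound 2 (0.50 log units; beyond the scatter). Compound 3 `CCc1nnc(-c2ccc(-c3ccccc3)cc2)n1-c1cccc(CO)c1C` carries hydroxymethyl in place of hydrogen on an aromatic carbon and gives 250 nM in this assay. Compound 3 holds the lowest of the three numbers, yet its separation from compound 1 is only a 1.2-fold lower number from compound 1 to compound 3 (0.08 log units; within the scatter), while its separation from compound 2 is a 3.8-fold lower number from compound 2 to compound 3 (0.58 log units; beyond the scatter).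

Compound 4 `CCc1nnc(-c2ccc(-c3ccccc3)cc2)n1-c1cccc(COC)c1C` has not been measured. It differs from compound 3 by methyl in place of hydrogen on an oxygen on a saturated carbon. The step bearing most directly on this change is a 3.8-fold lower number from compound 2 to compound 3 (0.58 log units; beyond the scatter), the one movement beyond the scatter in which a hydroxy entered on the saturated chain carbon; compound 4 now caps that same oxygen. The step of a 1.2-fold lower number from compound 1 to compound 3 (0.08 log units; within the scatter) shows that hydroxymethyl against bare hydrogen made no difference beyond the scatter. A small rise in the number, or none beyond the scatter, is therefore expected for compound 4, and the expected step is a 1.6-fold higher number from compound 3 to compound 4 (0.20 log units; within the scatter). Compound 4 is estimated at 400 nM in this assay, with a range from 150 nM to 1100 nM.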

Compound 4, half-maximal inhibitory concentration: 2400 nM
Beside the measured number, compound 4's estimate is 6.0-fold (0.78 log units) below it, outside the stated range (above it).
By their numbers in this assay, from the lowest: compounds 3 and 1 (each within the scatter of the next); then compound 2; then compound 4.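

Capping the oxygen is a far larger change than adding the hydroxymethyl group itself: in this assay, methyl on that oxygen gives a 9.6-fold higher number from compound 3 to compound 4 (0.98 log units; beyond the scatter), the largest step in the series so far, so this place accepts hydroxymethyl but not methoxymethyl without a clear loss. Methoxymethyl also falls behind both simpler groups, with a 2.6-fold higher number from compound 2 to compound 4 (0.41 log units; beyond the scatter) and an 8.0-fold higher number from compound 1 to compound 4 (0.90 log units; beyond the scatter), and the series hydrogen, methyl, hydroxymethyl, methoxymethyl shows no steady rise in the number as atoms are added, compound 3 being the one that goes against such a rise. No measurement at hand accounts for this step.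

The compounds shown leave open whether the rise goes with the loss of the hydrogen on the oxygen or with the entering methyl, since both occur in the one change. Also open, on these data alone, is how this place responds to an aminomethyl group, a carboxylic acid or a longer chain such as ethoxymethyl, any of which would show whether hydroxymethyl is a lone exception or part of a wider tolerance.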